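Moving the ring nitrogen: quinolin-7-yl to isoquinolin-6-yl

This account rests on a few compounds, and the source may have more. Where it says the series, first, only, none or still open, it means among the compounds named here.

Measured compounds:
- compound 1, `CN(C)C1(Cc2ccccc2)CCN(c2cc(C(F)(F)F)ccc2CNC(=O)Nc2cccc3ccc(O)cc23)CC1`: 8.9 nM
- compound 2, `CN(C)C1(Cc2ccccc2)CCN(c2cc(C(F)(F)F)ccc2CNC(=O)Nc2ccc3cccnc3c2)CC1`: 42 nM

Both compounds share one core and differ only in the aromatic group attached to the amide-type nitrogen. In an assay on CHO cells for antagonist activity at transient receptor potential cation channel subfamily V member 1 (Homo sapiens), read by scintillation counting, with a stated time of 5 min, in the presence of a further agent that is not named here (on this read-out higher numbers stand for an effect only at larger amounts of compound and lower numbers for an effect already at smaller amounts), compound 1 gives 8.9 nM. Within the data shown here, compound 2 carries a quinolin-7-yl group there, and in this assay compound 2 gives 42 nM, the higher of the two numbers; the only measured step, a 4.7-fold higher number from compound 1 to compound 2 (0.67 log units; beyond the scatter), shows how far it sits from compound 1.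

Compound 3, `CN(C)C1(Cc2ccccc2)CCN(c2cc(C(F)(F)F)ccc2CNC(=O)Nc2ccc3cnccc3c2)CC1`, is not yet measured. It differs from compound 2 in one place: isoquinolin-6-yl in place of quinolin-7-yl on an amide-type nitrogen. The two groups hold the same atoms, joined differently, so the change is a shift of the ring nitrogen within the same two-ring unit. No measured step tries this kind of change; the one step shown swaps a hydroxynaphthalenyl group for a quinolinyl group and is of a different nature, so it gives no direct guide.

Without a bearing step, compound 3 is expected to stay close to compound 2, the step of a 1.3-fold lower number from compound 2 to compound 3 (0.12 log units; within the scatter) being small and its direction uncertain. For compound 3 the estimate is 32 nM, within 10 nM to 110 nM.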

Compound 3, half-maximal effective concentration: 156 nM
Estimate against measurement, compound 3: 4.9-fold (0.69 log units) below; the whole stated range lies below it.
By their numbers in this assay, from the lowest: compound 1; then compound 2; then compound 3.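

In this assay, shifting only the ring nitrogen gives a 3.7-fold higher number from compound 2 to compound 3 (0.57 log units; beyond the scatter), although the leaving and entering groups hold the same atoms and the same counts of rings, donors and acceptors. At this position on the amide-type nitrogen, then, the number depends on where the nitrogen sits within the two-ring unit and not just on its presence, and replacing the 7-hydroxynaphthalen-1-yl group with isoquinolin-6-yl gives an 18-fold higher number from compound 1 to compound 3 (1.24 log units; beyond the scatter), so compound 2 and compound 3 do not stand equally far from compound 1 despite their shared atoms. Nothing available explains why the place of this nitrogen matters so much.

With only two placements of the nitrogen shown, these compounds cannot reveal how other arrangements, such as a quinolin-6-yl or isoquinolin-7-yl group, would behave. From the compounds shown here alone, it also remains open whether adding an amine to the isoquinolin-6-yl group would bring the number down, or whether the order seen here would hold for a different group on the shared core.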